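Trimming a Methyl from a Branched Substituent

The source may report more compounds than this note shows. Statements on the series, on what has been measured and on what is new or still open speak of the compounds shown alone.

Three compounds share one core and differ only in the group carried on the urea. Compound 1 `Cc1nc(N)sc1CCCN/C(N)=N/C(=O)N[C@@H](C)c1ccccc1`, compound 2 `Cc1nc(N)sc1CCCN/C(N)=N/C(=O)NC(c1ccccc1)C(C)C` and compound 3 `Cc1nc(N)sc1CCCN/C(N)=N/C(=O)NCC(C)CC1CCCCC1` were each tested in an assay on membranes from Sf9 cells for displacement of a labelled ligand from histamine H2 receptor (Homo sapiens), read by scintillation counting, with a stated time of 60 min; a lower number here means a stronger inhibitor, a higher number a weaker inhibitor. In this assay compound 1 gives 51.3 nM, compound 2 gives 35.5 nM and compound 3 gives 70.8 nM. Compound 2 holds the lowest of the three numbers, yet its gaps to compound 1 and to compound 3 both lie within the scatter, so no order among the three can be read from them.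

Compound 4 `CCC(NC(=O)/N=C(\N)NCCCc1sc(N)nc1C)c1ccccc1` has not yet been measured. It differs from compound 2 by hydrogen in place of methyl on a saturated chain carbon bound to two saturated chain carbons, a difference that, cut one bond further out, reads isopropyl to ethyl. Among the compounds with values here, no measured pair in this set shows such a step, so there is nothing to calibrate it against. Since compound 1 with 51.3 nM and compound 2 with 35.5 nM already sit close together, removing the methyl is expected to give no step beyond the scatter. The estimate for compound 4 in this assay is 45 nM, with a range of 20 nM to 110 nM. This corresponds to an expected 1.3-fold higher number from compound 2 to compound 4 (0.10 log units; within the scatter).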

Compound 4, inhibition constant: 63.1 nM
Beside the measured number, compound 4's estimate is 1.4-fold (0.15 log units) below it; measured number inside the range.
By their numbers in this assay, from the lowest: compounds 2, 1, 4 and 3 (each within the scatter of the next).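

Within the data shown here, the pair gives the first measured step at this position: in this assay, hydrogen in place of methyl on a saturated chain carbon bound to two saturated chain carbons, which reads isopropyl to ethyl, gives a 1.8-fold higher number from compound 2 to compound 4 (0.25 log units; within the scatter) and so stays within the scatter. Trimming this methyl from the branched substituent is therefore not shown to shift the number at this position, and the isopropyl and ethyl forms cannot be ranked. Nothing available bears on why the step has this size.

From the compounds shown here alone, whether another group at this carbon would step beyond the scatter stays open, for instance a hydroxyl, an amine or a longer chain such as butyl. Also open, going by these compounds, is whether the same trim would give a step of this size with a saturated ring in place of the phenyl.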